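This account rests on a few compounds, and the source may have more. Where it says the series, first, only, none or still open, it means among the compounds named here.

Compound 1, `CCCCC#Cc1cn([C@H]2C[C@H](O)[C@@H](CO)O2)c(=O)[nH]c1=O`, in a functional assay on L1210 cells (Mus musculus); on this read-out higher numbers stand for weaker inhibition and lower numbers for stronger inhibition: 1000 ug/mL.
Compound 2, `CCC#Cc1cn([C@H]2C[C@H](O)[C@@H](CO)O2)c(=O)[nH]c1=O`, in this assay: a limit of the assay, > 1000 ug/mL.
Compound 3, `CC#CCc1cn([C@H]2C[C@H](O)[C@@H](CO)O2)c(=O)[nH]c1=O`, in this assay: a limit of the assay, > 1000 ug/mL.

Going by the values given here, compound 1 carries the only number among the three; the other two sit at the limit of > 1000 ug/mL in this assay, at which 2 of the 3 values shown sit. Compound 4 is `O=c1[nH]c(=O)n([C@H]2C[C@H](O)[C@@H](CO)O2)cc1C#CCCCO` and differs from compound 1 by hydroxy in place of methyl on a saturated chain carbon, three bonds along the chain from a triple-bonded carbon. Among the compounds with values here, no measured step swaps a group for hydroxy: a number no lower from compound 1 to compound 2 (the limit leaves the size open) and a number no lower from compound 1 to compound 3 (the limit leaves the size open) alter the chain in other ways, and a step that the two limits leave unreadable from compound 2 to compound 3 is unreadable. Every measured step from compound 1 runs no lower. Compound 4 is therefore expected to stay near compound 1, with no change at the digits printed from compound 1 to compound 4 (within the scatter) as the estimated step, and it may well turn out to sit at a limit. The estimate for compound 4 is 1000 ug/mL, between 500 ug/mL and 2000 ug/mL.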

Compound 4, concentration for 50% inhibition: 280 ug/mL
The estimate for compound 4 lay 3.6-fold (0.55 log units) above the measured number, outside the stated range (below it).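

In this assay, going by these compounds alone, hydroxy in place of methyl on a saturated chain carbon, three bonds along the chain from a triple-bonded carbon, gives a 3.6-fold lower number from compound 1 to compound 4 (0.55 log units; beyond the scatter), the only step from compound 1 whose size can be read and the only one toward stronger inhibition. The steps of an at least 3.5-fold lower number from compound 2 to compound 4 (0.55 log units; beyond the scatter) and an at least 3.5-fold lower number from compound 3 to compound 4 (0.55 log units; beyond the scatter) run the same way, and both rest on limits of the assay: the limit of > 1000 ug/mL in this assay, at which 2 of the 4 values shown sit. The end of this chain is thus a place where a single swap of one heavy atom shifts the read-out beyond the scatter.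

The compounds shown leave open whether the gain belongs to hydroxy itself or to its place on the chain. An amine or a carboxylic acid at the same chain end, or a longer chain ending in hydroxy, would separate the two.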